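Trifluoromethyl on the fused ring of compound 2

This account rests on a few compounds, and the source may have more. Where it says the series, first, only, none or still open, it means among the compounds named here.

Measured so far:
compound 1 `Clc1cccc(Nc2nccc3occc23)c1` — 371 nM
compound 2 `Clc1cccc(Nc2n[nH]c3ccccc23)c1` — 84 nM

In an assay for inhibition of acyl-CoA (8-3)-desaturase (Homo sapiens) (a lower number here means a stronger inhibitor, a higher number a weaker inhibitor), compound 2 gives the lowest of the two numbers; compound 1 gives 371 nM, and that gap lies beyond the scatter. Compound 3 `FC(F)(F)c1ccc2[nH]nc(Nc3cccc(Cl)c3)c2c1` keeps the core of compound 2 and differs only by trifluoromethyl in place of hydrogen on an aromatic carbon. For the measured compounds named here, no measured pair shows the effect of this change, so the direction is open. A modest step is expected, a 1.4-fold lower number from compound 2 to compound 3 (0.15 log units; within the scatter), not clearly beyond the scatter. Compound 3 is estimated at 60 nM in this assay, within 15 nM to 250 nM.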

Compound 3, half-maximal inhibitory concentration: 254 nM
The estimate for compound 3 lay 4.2-fold (0.63 log units) below the measured number; the measured number lies above the stated range.
By their numbers in this assay, from the lowest: compound 2; then compounds 3 and 1 (each within the scatter of the next).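

In this assay, for the compounds shown here, trifluoromethyl in place of hydrogen on an aromatic carbon gives a 3.0-fold higher number from compound 2 to compound 3 (0.48 log units; beyond the scatter) and so provides the first single-change step, one beyond the scatter. This carbon of the core of compound 2 is therefore sensitive to substitution, and with this group inhibition weakens. No available measurement bears on the reason for the loss. Still open, on these data alone, is whether fluorine, a methoxy group or an amine on this carbon would also weaken inhibition. Also open, as far as these compounds go, is whether trifluoromethyl on another carbon of the same ring would do the same.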